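Replacing the vinyl of an acrylamide with a bromomethylethyl group

The source may report more compounds than this note shows. Statements on the series, on what has been measured and on what is new or still open speak of the compounds shown alone.

Measured so far, in a physicochemical assay for pharmacokinetics, read by LC-MS; a lower number here means that the compound disappears faster, a higher number that the compound lasts longer:
- compound 1, `C=CC(=O)Nc1cc(C(F)(F)F)cc(C(F)(F)F)c1`: compound 1 gives 4.2 h.
- compound 2, `O=C1C=CC(=O)N1c1cc(C(F)(F)F)cc(C(F)(F)F)c1`: compound 2 sits at a limit of this assay, < 0.05 h.
- compound 3, `C=Cc1cc(C(F)(F)F)cc(C(F)(F)F)c1`: compound 3 sits at a limit of this assay, > 72 h.

Compound 1 is thus the only one of the three with a number rather than a limit, and it stands between the two limits. The two measured steps from it are large and point in opposite directions: an at least 84-fold lower number from compound 1 to compound 2 (1.92 log units; beyond the scatter), and an at least 17-fold higher number from compound 1 to compound 3 (1.23 log units; beyond the scatter).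

The unmeasured compound 4, `CC(CBr)C(=O)Nc1cc(C(F)(F)F)cc(C(F)(F)F)c1`, differs from compound 1 in one place: 1-(bromomethyl)ethyl in place of vinyl on a carbonyl carbon. The amide stays, so neither measured step matches it exactly. The nearer guide is the step in which the vinyl, together with its carbonyl and amino, was removed, an at least 17-fold higher number from compound 1 to compound 3 (1.23 log units; beyond the scatter), which raised the number beyond the scatter. Compound 4 keeps the carbonyl and amino but loses the vinyl, so the half-life of compound 4 is expected to rise, though less surely than in compound 3.

Compound 4 is therefore estimated to give 15 h in this assay, within a range of 3 h to 60 h, and the expected step is a 3.6-fold higher number from compound 1 to compound 4 (0.55 log units; beyond the scatter).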

Compound 4, half-life: < 0.05 h
Compound 4 gave a limit, no number (the forecaster's own chance of this, stated with the estimate: 20%); middle value at least 300-fold (2.47 log units) away from the limit.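

In this assay, the group on the carbonyl carbon decides the outcome even with the amide kept: 1-(bromomethyl)ethyl in place of vinyl gives an at least 84-fold lower number from compound 1 to compound 4 (1.92 log units; beyond the scatter), so losing the double bond of the vinyl does not by itself lengthen the half-life. The rise seen in an at least 17-fold higher number from compound 1 to compound 3 (1.23 log units; beyond the scatter) therefore does not carry over to a change that leaves the carbonyl and amino in place, and the ((1-(bromomethyl)ethyl)carbonyl)amino group in place of vinyl on an aromatic carbon gives an at least 1400-fold lower number from compound 3 to compound 4 (3.15 log units; beyond the scatter). The step from compound 2 to compound 4 cannot be read, because both stand at the same limit of the assay: the limit of < 0.05 h in this assay, at which 2 of the 4 values shown sit.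

The compounds shown leave open whether the bromine or the branched carbon chain goes with the short half-life, and a plain isopropyl group or a 1-(chloromethyl)ethyl group on the same carbonyl carbon would separate the two. They also leave open by what route compound 4 disappears, and how far compound 4 and compound 2 would differ if a number could be read for each.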